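The compounds below may be only part of what the source reports. "The series", "measured", "known", "first", "only" and "open" are said of these compounds alone.

Compound 1 `O=S(=O)(Nc1ccncc1Nc1cccc(Br)c1)C(F)(F)F` and compound 2 `O=S(=O)(Nc1ccncc1Nc1cccc(Cl)c1)C(F)(F)F` share one core and differ only in a bromo against a chloro on the outer ring. In a functional assay on the whole organism (strain Wistar) with Rattus norvegicus as the target, with stated times of 30 min and 4 h, at a dose of 10 mg/kg by the intraperitoneal route (on this read-out lower numbers stand for a weaker effect and higher numbers for a stronger effect at the one dose given), compound 1 gives 27.1%, while compound 2 is reported as "not active" (no number reported), so no single number marks where compound 2 stands. Compound 3 `Cc1cccc(Nc2cnccc2NS(=O)(=O)C(F)(F)F)c1` follows from compound 2 by one change: methyl in place of chloro on an aromatic carbon. For the measured compounds named here, with compound 2 reported as "not active" (no number reported) and no measured step to compare, only a step within the usual scatter, in no clear direction, is expected in this assay. Compound 3 is expected to give about 10%, between 0% and 30%.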

Compound 3, a percentage reported as activity, at one dose (the size of the read-out at that dose, not a potency): 25%
For compound 3 the middle estimate is 15 percentage points below the measured one; low and high end bracket the measured number.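

In this assay putting methyl in place of bromo gives a number 2.1 percentage points lower from compound 1 to compound 3 (within the scatter) and so, on this aromatic carbon, these two groups cannot be told apart at the one dose given. The step from compound 2 to compound 3 cannot be read, since compound 2 has no number. Nothing measured here explains the behaviour of these groups. Still open, on these data alone, is what an amine, a methoxy group or a longer chain on this carbon would give, and whether compound 3 would keep its level at other doses.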